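Moving a trifluoromethoxy group around the amide-bound ring

This account rests on a few compounds, and the source may have more. Where it says the series, first, only, none or still open, it means among the compounds named here.

Compound 1 `Cc1ccc(C(=O)Nc2ccc(Cl)cc2)cc1C#Cc1cc(-c2cnn(C)c2)cnc1N`: 269 nM
Compound 2 `Cc1ccc(C(=O)Nc2cccc(C(F)(F)F)c2)cc1C#Cc1cc(-c2cnn(C)c2)cnc1N`: 7 nM
Compound 3 `Cc1ccc(C(=O)Nc2cccc(OC(F)(F)F)c2)cc1C#Cc1cc(-c2cnn(C)c2)cnc1N`: 33.7 nM

These three share one core and differ only in the ring on the amide-type nitrogen, tested in an ADME assay on RBL-2H3 cells (Rattus norvegicus) for cytotoxicity, read by CCK-8 assay, with a stated time of 24 h; on this read-out higher numbers stand for lower toxicity in this test and lower numbers for higher toxicity in this test. Compound 3 sits second highest: compound 2 lies below it by a 4.8-fold higher number from compound 2 to compound 3 (0.68 log units; beyond the scatter), compound 1 above it by an 8.0-fold lower number from compound 1 to compound 3 (0.90 log units; beyond the scatter). Compound 4 `Cc1ccc(C(=O)Nc2ccc(OC(F)(F)F)cc2)cc1C#Cc1cc(-c2cnn(C)c2)cnc1N` carries 4-(trifluoromethoxy)phenyl in place of 3-(trifluoromethoxy)phenyl on an amide-type nitrogen. Going by the values given here, no measured step moves a group from one position to another on this ring; compound 1, the only other compound with a group at the 4-position, gives the highest number, so a modest rise is expected, a 2.1-fold higher number from compound 3 to compound 4 (0.32 log units; beyond the scatter). Compound 4 is estimated at 70 nM, between 20 nM and 250 nM.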

Compound 4, half-maximal cytotoxic concentration: 41 nM
Compound 4: the middle estimate sits 1.7-fold (0.23 log units) above what was measured; low and high end bracket the measured number.
By their numbers in this assay, from the lowest: compound 2; then compounds 3 and 4 (each within the scatter of the next); then compound 1.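

Shifting the trifluoromethoxy group to give the 4-(trifluoromethoxy)phenyl ring produces a 1.2-fold higher number from compound 3 to compound 4 (0.09 log units; within the scatter), so in this test the two positions cannot be told apart for this group. The group itself matters more: trifluoromethoxy in place of chloro gives a 6.6-fold lower number from compound 1 to compound 4 (0.82 log units; beyond the scatter). Replacing 3-(trifluoromethyl)phenyl with this ring gives a 5.9-fold higher number from compound 2 to compound 4 (0.77 log units; beyond the scatter), so both trifluoromethoxy isomers remain separate from compound 2.

Nothing shown explains these differences. From the compounds shown here alone, how 4-(trifluoromethyl)phenyl, or a ring carrying an amine, would read remains open.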